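A few compounds are considered here, and "the series" means these few. Any claim that something is new, unique, unknown or untested is made for them only; others in the source may bear on it.

Compound 1 `COc1ccc(NC(=O)c2cccc(/C=C3\CC(=O)N(c4ccccc4)C3=O)c2)cc1`: > 100000 nM
Compound 2 `CSc1cccc(NC(=O)c2cccc(/C=C3\CC(=O)N(c4ccccc4)C3=O)c2)c1`: > 100000 nM

In an ADME assay on NCM460 cells (Homo sapiens) for cytotoxicity, read by MTT assay, with a stated time of 72 h (a higher number here means a weaker inhibitor, a lower number a stronger inhibitor), compound 1 gives > 100000 nM, which is a limit of the assay rather than a number. In the same test compound 2 gives > 100000 nM, again a limit. Both share one core, and the step between them, a step that the two limits leave unreadable from compound 1 to compound 2, cannot be read because both ends sit at the limit of > 100000 nM in this assay, at which 2 of the 2 values shown sit. Compound 2 therefore stands at that limit, with no readable number of its own.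

Compound 3 `O=C(Nc1ccc(Cl)cc1)c1cccc(/C=C2\CC(=O)N(c3ccccc3)C2=O)c1` carries the change (4-chlorophenyl in place of 3-(methylsulfanyl)phenyl on an amide-type nitrogen). Among the measured compounds shown here, the only measured step touches the same amide-type nitrogen, and its size is not readable, so it offers no guide to direction or size; nothing among the measured compounds points to a readable step here. Compound 3 is therefore expected to behave like compound 2, as a step that the limit leaves unreadable from compound 2 to compound 3 that stays within the scatter. The estimate for compound 3 is 150000 nM, with a range from 60000 nM to 400000 nM, and most likely the assay will again report only a limit.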

Compound 3, half-maximal inhibitory concentration: > 100000 nM
Compound 3 ended at the assay's limit; the forecaster's own chance of this, stated with the estimate: 80%; the middle value does not contradict the limit.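

In this assay compound 3 gives > 100000 nM, which is a limit and not a number. Among the compounds shown here, no step among compound 1, compound 2 and compound 3 can be read: the limit of > 100000 nM in this assay, at which 3 of the 3 values shown sit. The compounds shown leave open whether any change of the group on the amide-type nitrogen alters this read-out at all.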